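Inverting a Ring Stereocentre on the Path to Compound 4

The source may report more compounds than this note shows. Statements on the series, on what has been measured and on what is new or still open speak of the compounds shown alone.

Within the data shown here, in an ADME assay on microsomes from liver (Mus musculus) for metabolic stability, read by LC-MS, with a stated time of 10 min, tested at 0.5 uM (a lower number here means that less of the compound is left, a higher number that more of the compound is left), compound 2 `c1cnc2c(c1)CN[C@H](CN(CCCN1CCNCC1)[C@H]1CCCc3cccnc31)C2` gives 63%, the second highest of the three numbers known. Its nearest neighbour is compound 1 `c1cnc2c(c1)CCC[C@@H]2N(CCCN1CCNCC1)Cc1nc2ccccc2[nH]1`, which gives 68% in this assay, the step being a number 5 percentage points lower from compound 1 to compound 2 (within the scatter). Furthest away is compound 3 `CN1CCN(CCCN(C[C@H]2Cc3ccccc3CN2C)[C@H]2CCCc3cccnc32)CC1`, which gives 43% in this assay. Compound 4 `c1cnc2c(c1)CN[C@@H](CN(CCCN1CCNCC1)[C@H]1CCCc3cccnc31)C2` differs from compound 2 only in configuration: the two compounds have the same atoms and bonds and differ only in configuration as drawn: 1 of 2 stereo elements differ; a stereocentre at a saturated ring carbon is drawn S in compound 2 and R in compound 4. Among the measured compounds shown here, no measured step alters a stereocentre alone; the one single-place step, a number 5 percentage points lower from compound 1 to compound 2 (within the scatter), exchanges whole groups and stays within the scatter. Compound 4 is therefore expected to show no step beyond the scatter, a number 1 percentage points lower from compound 2 to compound 4 (within the scatter). The estimate for compound 4 is 62%, within a range of 48% to 76%.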

Compound 4, percent of the compound remaining: 78%
The estimate for compound 4 lay 16 percentage points below the measured number; measured number above the stated range.
By their numbers in this assay, from the lowest: compound 3; then compounds 2, 1 and 4 (each within the scatter of the next, the first and the last beyond it).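

In this assay, among these compounds, the stereocentre at a saturated ring carbon, drawn S in compound 2 and R in compound 4, is enough on its own for a number 15 percentage points higher from compound 2 to compound 4 (beyond the scatter), which the earlier steps, all exchanging whole groups, did not show. The exchange of groups stays within the scatter even with the R drawing: a number 10 percentage points higher from compound 1 to compound 4 (within the scatter). The gain belongs to this stereocentre because nothing else separates the pair: the fact that compounds 2 and 4 differ only in the configuration as drawn.

Going by these compounds, whether the inversion gives a like step with a fluorine or a hydroxyl group on the shared core stays open. On these data alone, the other stereocentre's role also remains unknown.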